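The compounds below may be only part of what the source reports. "The series", "measured", "known", "first", "only" and "open" are said of these compounds alone.

Compound 1 `O=C1NCCC12CCN(c1c(Cl)cncc1-c1cccs1)CC2` gives 480 nM in a functional assay on MV4-11 cells (Homo sapiens) for inhibition, read by resazurin assay, with a stated time of 72 h (a higher number here means a weaker inhibitor of growth, a lower number a stronger inhibitor of growth), the lowest of the three numbers recorded. Compound 2 `O=C1NCCC12CCN(c1c(Cl)cncc1-c1cc[nH]c1)CC2` gives 1050 nM in this assay, and compound 3 `O=C1NCCC12CCN(c1c(Cl)cncc1-c1cn[nH]c1)CC2` gives 8520 nM. The steps are a 2.2-fold higher number from compound 1 to compound 2 (0.34 log units; beyond the scatter), an 18-fold higher number from compound 1 to compound 3 (1.25 log units; beyond the scatter) and an 8.1-fold higher number from compound 2 to compound 3 (0.91 log units; beyond the scatter), so each exchange of the thiophen-2-yl ring for a five-membered ring with nitrogen has raised the number, and the 1H-pyrazol-4-yl ring has done so most.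

Compound 4 `Cn1cc(-c2cncc(Cl)c2N2CCC3(CCNC3=O)CC2)cn1` is not yet measured. It differs from compound 1 by 1-methyl-1H-pyrazol-4-yl in place of thiophen-2-yl on an aromatic carbon. The entering group, as counted, carries no hydrogen-bond donor and two hydrogen-bond acceptors, and it shares its two-nitrogen ring with compound 3 while resembling compound 2 in lacking a ring hydrogen on nitrogen. The steps to compound 2 and to compound 3 both point upward, so a rise beyond the scatter is expected, most likely between the sizes of those two. Compound 4 is therefore expected to give about 3000 nM in this assay, in the range 1000 nM to 9000 nM, an estimated step of a 6.3-fold higher number from compound 1 to compound 4 (0.80 log units; beyond the scatter).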

Compound 4, concentration for 50% growth inhibition: 5530 nM
Beside the measured number, compound 4's estimate is 1.8-fold (0.27 log units) below it, within the range that was stated.
By their numbers in this assay, from the lowest: compound 1; then compound 2; then compounds 4 and 3 (each within the scatter of the next).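

In this assay, going by these compounds alone, methyl in place of hydrogen on the aromatic nitrogen of the 1H-pyrazol-4-yl ring gives no difference that can be read (a 1.5-fold lower number from compound 3 to compound 4 (0.19 log units; within the scatter)), which the earlier compounds could not show. With that nitrogen methylated, the ring still stands well apart from thiophen-2-yl (a 12-fold higher number from compound 1 to compound 4 (1.06 log units; beyond the scatter)) and from 1H-pyrrol-3-yl (a 5.3-fold higher number from compound 2 to compound 4 (0.72 log units; beyond the scatter)), so a hydrogen on that nitrogen is not needed for the higher number among these compounds. Nothing available here gives a reason for these steps.

From the compounds shown here alone, it remains open whether a longer chain or a chain ending in an amine on that nitrogen would stand apart from methyl. Also open, going by these compounds, is how furan-2-yl or phenyl would compare with thiophen-2-yl at this position on the core of compound 1.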